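This account rests on a few compounds, and the source may have more. Where it says the series, first, only, none or still open, it means among the compounds named here.

Measured compounds in a functional assay on A549 cells (Homo sapiens) for antiproliferative activity, read by MTT assay, with a stated time of 24 h; a higher number here means a weaker inhibitor, a lower number a stronger inhibitor:
Compound 1 `COc1ccc(C(=O)/C=C/c2cc(-c3ccc(OC)c(OC)c3)n3nc(-c4ccccc4)cc3n2)cc1OC` gives 3900 nM.
Compound 2 `COc1cc(-c2cc(/C=C/C(=O)c3ccc(C)c(C)c3)nc3cc(-c4ccccc4)nn23)cc(OC)c1OC` gives 10600 nM.
Compound 3 `COc1ccc(-c2cc(/C=C/C(=O)c3ccc(C)cc3)nc3cc(-c4ccccc4)nn23)cc1OC` gives 17200 nM.

Compound 2 stands second highest of the three numbers. Its nearest neighbour is compound 3, whose value sits within the scatter of compound 2, so no order is drawn between them; compound 1 lies beyond the scatter, lower than compound 2. Compound 4 `COc1cc(-c2cc(/C=C/C(=O)c3ccccc3)nc3cc(-c4ccccc4)nn23)cc(OC)c1OC` differs from compound 2 in one place: phenyl in place of 3,4-dimethylphenyl on a carbonyl carbon. For the measured compounds named here, only one measured step alters the group on the carbonyl carbon, a 4.4-fold higher number from compound 1 to compound 3 (0.64 log units; beyond the scatter), and it exchanges a methoxy-bearing ring for a methyl-bearing one, not a methyl-bearing ring for a bare phenyl. Compound 2 and compound 3 carry a 3,4-dimethylphenyl and a 4-methylphenyl at that carbonyl carbon, with values within the scatter of each other, though they also differ elsewhere. The closest comparison thus points to a small shift at most; compound 4 is expected to show a 1.3-fold higher number from compound 2 to compound 4 (0.12 log units; within the scatter), a step not beyond the scatter. Compound 4 is therefore estimated at 14000 nM, in the range 6000 nM to 35000 nM.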

Compound 4, half-maximal inhibitory concentration: 18200 nM
Estimate against measurement, compound 4: 1.3-fold (0.11 log units) below, within the range that was stated.
By their numbers in this assay, from the lowest: compound 1; then compounds 2, 3 and 4 (each within the scatter of the next).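

In this assay, the exchange of 3,4-dimethylphenyl for phenyl on the carbonyl carbon reads a 1.7-fold higher number from compound 2 to compound 4 (0.23 log units; within the scatter), so no order is drawn between these two compounds. For the compounds shown here, this is the first step at this position with the rest of the molecule unchanged to stay within the scatter, unlike the only earlier step there, a 4.4-fold higher number from compound 1 to compound 3 (0.64 log units; beyond the scatter), which exchanged a 3,4-dimethoxyphenyl for a 4-methylphenyl. No measurement shown here offers an explanation for this result.

The compounds shown leave open whether 3,4-dimethoxyphenyl on the carbonyl carbon would move the number beyond the scatter on the core of compound 2, as that group appears only in compound 1. They also leave open what a ring bearing an amine or a carboxylic acid would give at this position.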